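Swapping the Ethoxy Arm of a Dithiocarbonate Ester

The compounds below may be only part of what the source reports. "The series", "measured", "known", "first", "only" and "open" are said of these compounds alone.

Measured compounds:
- compound 1, `CCOC(=S)SCC(=O)c1ccc(OC)cc1`: 4640 nM
- compound 2, `CCOC(=S)SCC(=O)c1ccc(NC(C)=O)cc1`: 3610 nM
- compound 3, `CCSC(=S)SCC(=O)c1cccc(CNC(C)=O)c1`: 11300 nM

In a functional assay on HeLa cells (Homo sapiens) for cytotoxicity, read by resazurin assay, with a stated time of 72 h (a lower number here means a stronger inhibitor, a higher number a weaker inhibitor), compound 1 gives 4640 nM, the second highest of the three numbers. Its nearest neighbour is compound 2, where the step of a 1.3-fold lower number from compound 1 to compound 2 (0.11 log units; within the scatter) comes from acetamido in place of methoxy on an aromatic carbon. Among the measured compounds shown here, compound 3 gives the highest number, but it differs from compound 1 in more than one place, so its value shows only that a compound of this family can reach a weaker result.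

Compound 4, `COCCSC(=S)SCC(=O)c1ccc(OC)cc1`, has not yet been measured. It differs from compound 1 by (2-methoxyethyl)sulfanyl in place of ethoxy on a thiocarbonyl carbon. No measured step touches the thiocarbonyl carbon while leaving the rest of the molecule unchanged, so the listed data give no direct guide. For the measured compounds named here, the only single step known, from compound 1 to compound 2, sits on the aromatic ring and lies within the scatter. For compound 4 in this assay the expected step is a 1.4-fold higher number from compound 1 to compound 4 (0.15 log units; within the scatter), a modest move towards a higher number that may still fall within the scatter. The estimate for compound 4 is 6500 nM, with a range from 2500 nM to 17000 nM.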

Compound 4, half-maximal inhibitory concentration: 7880 nM
Compound 4: middle estimate off by 1.2-fold (0.08 log units), on the low side; the range from low to high includes it.
By their numbers in this assay, from the lowest: compounds 2, 1, 4 and 3 (each within the scatter of the next, the first and the last beyond it).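

In this assay, among the compounds shown here, the first step that touches the thiocarbonyl carbon alone is a 1.7-fold higher number from compound 1 to compound 4 (0.23 log units; within the scatter), so compound 1 and compound 4 cannot be told apart in this assay. For this one pair, then, the position accepts (2-methoxyethyl)sulfanyl in place of ethoxy, a larger arm that also brings in sulfur, without a change that stands clear of the usual scatter of repeat measurements. No measurement shown bears on how either arm acts in these cells.

This swap alters the atom bonded to the thiocarbonyl carbon and the chain in a single move, so the compounds shown cannot separate the two. On these data alone, how an amine or a longer plain carbon chain on the thiocarbonyl carbon would read on the core of compound 1 remains open.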